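Lengthening the Acyl Chain on a Shared Nucleoside Core

The compounds below may be only part of what the source reports. "The series", "measured", "known", "first", "only" and "open" are said of these compounds alone.

Of the compounds shown here, three sharing one core have been tested in a functional assay on SW1573 cells (Homo sapiens) for cytotoxicity, read by sulforhodamine B assay, with a stated time of 72 h; a lower number here means a stronger inhibitor, a higher number a weaker inhibitor. Compound 1 `CC(=O)Nc1ccn([C@@H]2CO[C@H](CO)O2)c(=O)n1` gives 10700 nM, and compound 2 `CCCC(=O)Nc1ccn([C@@H]2CO[C@H](CO)O2)c(=O)n1` gives 8070 nM. The change between them, (ethyl in place of hydrogen on a saturated chain carbon bound to a carbonyl carbon), produced a 1.3-fold lower number from compound 1 to compound 2 (0.12 log units; within the scatter). Compound 3 `CCCCCCCCCCCCCCCC(=O)Nc1ccn([C@@H]2CO[C@H](CO)O2)c(=O)n1` gives 20 nM, far stronger than either; the difference between the core of compound 1 and that of compound 3 is not broken down here. Compound 4 `CCCCCCCCCCCCCCCCCC(=O)Nc1ccn([C@@H]2CO[C@H](CO)O2)c(=O)n1` awaits testing in this assay. It differs from compound 3 by ethyl in place of hydrogen on a saturated chain carbon, ten or more bonds along the chain from a carbonyl carbon, the same kind of change as before, though the place on the chain differs. For compound 4 a small step of no change at the digits printed from compound 3 to compound 4 (within the scatter) is expected, resting on the earlier small step. Compound 4 is thus estimated at 20 nM, between 8 nM and 50 nM.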

Compound 4, half-maximal inhibitory concentration: 125 nM
Estimate against measurement, compound 4: 6.3-fold (0.80 log units) below; the measured number lies above the stated range.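

Placing ethyl in place of hydrogen on a saturated chain carbon, ten or more bonds along the chain from a carbonyl carbon, gave in this assay a 6.3-fold higher number from compound 3 to compound 4 (0.80 log units; beyond the scatter). This weakening means the change did not carry over with the same size from one core to another in this series: the same change on two cores in this assay, a 1.3-fold lower number (0.12 log units; within the scatter) from compound 1 to compound 2 and a 6.3-fold higher number (0.80 log units; beyond the scatter) from compound 3 to compound 4, 8.3-fold (0.92 log units) apart, beyond the scatter of two such steps. Within the data shown here, with only two steps, and the change sitting at a different place on the chain in each, the data do not show whether that place, the chain already present, or something else sets the size of the step.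

The compounds shown leave open how a chain of middling length would behave, and whether a still longer chain would weaken inhibition further. They also leave open how a chain carrying an amine or a carboxylic acid would compare.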